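The source may report more compounds than this note shows. Statements on the series, on what has been measured and on what is new or still open speak of the compounds shown alone.

Two analogues of a shared core carry the same acid-end chain and differ only in the aromatic groups around the five-membered aromatic ring with 3 nitrogen. Compound 1 `Cc1ccccc1-n1nc(-c2ccccc2)nc1CNc1ccc(C(=O)NO)cc1` in an assay on Sf9 cells for inhibition of protein deacetylase HDAC6 (Homo sapiens), read by fluorescence, with a stated time of 40 min, tested at 100 nM (a lower number here means less inhibition, a higher number more inhibition at the concentration tested (going by the name of the read-out)), gives 57.1%, and compound 2 `O=C(NO)c1ccc(NCc2nc(-c3cccnc3)nn2-c2ccccc2)cc1` in this assay gives 57.7%. Compound 2 holds the higher of the two numbers, but its gap to compound 1 lies within the scatter, so the two values show the same level of inhibition. Within the data shown here, compound 1 and compound 2 differ in two places at once, so no single step between them can be read. Compound 3 `Cc1ccccc1-c1nc(CNc2ccc(C(=O)NO)cc2)n(-c2ccccc2)n1` differs from compound 2 by 2-methylphenyl in place of pyridin-3-yl on an aromatic carbon. Because compound 1, which also carries a 2-methylphenyl on the core, gives 57.1%, a number matching compound 2, no step beyond the scatter is expected in this assay. For compound 3 the expected step is a number 0.7 percentage points lower from compound 2 to compound 3 (within the scatter). Compound 3 is estimated at 57%, between 42% and 72%.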

Compound 3, a percentage reported as inhibition, at one concentration (the size of the read-out at that concentration, not a potency): 53.2%
The estimate for compound 3 lay 3.8 percentage points above the measured number, and the stated range covers the measured number.
By their numbers in this assay, from the lowest: compounds 3, 1 and 2 (each within the scatter of the next).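

On the aromatic carbon between two ring nitrogen atoms, 2-methylphenyl in place of pyridin-3-yl gives a number 4.5 percentage points lower from compound 2 to compound 3 (within the scatter) in this assay. Among these compounds, this is the first change that can be read at a single place, and it shows that exchanging a ring with one hetero atom for a ring of carbon only, with the loss of the hydrogen-bond acceptor counted on pyridin-3-yl, does not move the read-out beyond the scatter. No measured data bear on the reason for this result.

As far as these compounds go, whether the level of inhibition holds with a non-aromatic group at this carbon, such as an amine, a carboxylic acid or a longer chain, remains open. From the compounds shown here alone, the read-out comes from one concentration, so any difference in potency between compound 2 and compound 3 also remains open.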